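The compounds below may be only part of what the source reports. "The series", "measured", "known", "first", "only" and "open" are said of these compounds alone.

Compound 3 `N#Cc1ccccc1Cn1ccc2nc(-c3ccccc3)nc-2c1` stands in an ADME assay on MDBK cells (Bos taurus) for cytotoxicity (a lower number here means that less compound is tolerated, a higher number that more compound is tolerated), at > 100000 nM, which is a limit of the assay and not a number. Compound 1 `Fc1ccc(Cn2ccc3nc(-c4ccccc4)nc-3c2)cc1` gives > 100000 nM, also a limit. Compound 2 `Clc1ccccc1Cn1ccc2nc(-c3ccccc3)nc-2c1` gives > 100000 nM, again a limit. The whole measured series therefore comes down to a single reading: the limit of > 100000 nM in this assay, at which 3 of the 3 values shown sit.

Compound 4 `N#Cc1ccc(Cn2ccc3nc(-c4ccccc4)nc-3c2)cc1` has the same atoms as compound 3, joined differently, and the change lies on a saturated chain carbon bound to an aromatic nitrogen: 4-cyanophenyl in place of 2-cyanophenyl on a saturated chain carbon bound to an aromatic nitrogen.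

Three measured changes bear on this one: a step that the two limits leave unreadable from compound 1 to compound 2, a step that the two limits leave unreadable from compound 2 to compound 3 and a step that the two limits leave unreadable from compound 1 to compound 3. None of them has a size that can be read, so they give no direction. Still, swapping the ring on that same chain carbon has not yet brought any compound off the limit, so no step beyond the scatter is expected in this assay, in either direction. The expected change is a number no higher from compound 3 to compound 4 (the limit leaves the size open). For compound 4 the estimate is 100000 nM, with an expected range from 50000 nM to 200000 nM.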

Compound 4, half-maximal cytotoxic concentration: > 100000 nM
Compound 4: no number, only a limit; the forecaster's own chance of this, stated with the estimate: 85%; the middle value sits exactly at the limit.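

Compound 4 gives > 100000 nM, which is a limit of the assay and not a number. The steps to it from compound 1, compound 2 and compound 3 therefore cannot be read. The compounds shown leave open how much of any of them is actually tolerated in this assay, and whether any change on the saturated chain carbon would bring a compound off this limit.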